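Series notes: the step from compound 3 to compound 4

The compounds below may be only part of what the source reports. "The series", "measured", "known", "first", "only" and "open" are said of these compounds alone.

Measured values in a physicochemical assay for lipophilicity (on this read-out higher numbers stand for higher lipophilicity and lower numbers for lower lipophilicity), follow
- compound 1 `C[C@H]1CC[C@@H]2[C@@H](OC(=O)[C@]23CC(c2ccc(N(C)C)cc2)=NO3)[C@]2(C)C(=O)C=C[C@@]12O` gives 1.51
- compound 2 `C[C@H]1CC[C@@H]2[C@@H](OC(=O)[C@]23CC(c2ccc(O)cc2)=NO3)[C@]2(C)C(=O)C=C[C@@]12O` gives 0.932
- compound 3 `C[C@H]1CC[C@@H]2[C@@H](OC(=O)[C@]23CC(c2ccccc2[N+](=O)[O-])=NO3)[C@]2(C)C(=O)C=C[C@@]12O` gives 1.37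

Compound 3 lies within the scatter of compound 1 and clearly above compound 2. The change 4-hydroxy-3-methoxyphenyl in place of 2-nitrophenyl on a carbon with a double bond to nitrogen leads to compound 4 `COc1cc(C2=NO[C@]3(C2)C(=O)O[C@@H]2[C@H]3CC[C@H](C)[C@]3(O)C=CC(=O)[C@@]23C)ccc1O` with 4-hydroxy-3-methoxyphenyl in place of 2-nitrophenyl. Among the measured compounds shown here, the nearest precedent, read in reverse, is a number 0.44 log units higher from compound 2 to compound 3 (beyond the scatter) with 4-hydroxyphenyl leaving and 2-nitrophenyl entering. Also relevant is a number 0.58 log units lower from compound 1 to compound 2 (beyond the scatter) with hydroxy entering. For the measured compounds named here, no measured compound carries the methoxy group, so its contribution is unknown. A modest fall is expected, and the estimated change is a number 0.37 log units lower from compound 3 to compound 4 (beyond the scatter) in this assay on this reading. Compound 4 is estimated at 1 with 0.7 to 1.35 as the expected range.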

Compound 4, partition coefficient: 0.75
Beside the measured number, compound 4's estimate is 0.25 log units above it, and the stated range covers the measured number.
By their numbers in this assay, from the lowest: compounds 4 and 2 (each within the scatter of the next); then compounds 3 and 1 (each within the scatter of the next).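

In this assay, among the compounds shown here, the methoxy group, absent from the earlier compounds, gives only a step within the scatter on the hydroxyphenyl (a number 0.18 log units lower from compound 2 to compound 4 (within the scatter)). The 4-hydroxy-3-methoxyphenyl group on this carbon gives clear steps against both 2-nitrophenyl (a number 0.62 log units lower from compound 3 to compound 4 (beyond the scatter)) and 4-(dimethylamino)phenyl (a number 0.76 log units lower from compound 1 to compound 4 (beyond the scatter)). No measurement at hand explains these steps.

Open, on these data alone, is whether a methoxyphenyl without the hydroxy, or a phenyl bearing a carboxylic acid, would fall with compounds 2 and 4 or with compounds 1 and 3.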